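The compounds below may be only part of what the source reports. "The series", "measured", "known", "first", "only" and "open" are said of these compounds alone.

Working notes on a small set built around one shared core. Compound 1 `O=C(CCCc1ccccc1)Nc1nc2ccc(Cl)cc2c(=O)s1` carries a chloro on the fused ring and a saturated chain ending in phenyl. In an assay on CHO cells for displacement of a labelled ligand from adenosine receptor A3 (Homo sapiens), read by scintillation counting, with a stated time of 60 min (a lower number here means a stronger inhibitor, a higher number a weaker inhibitor), compound 1 gives > 1000 nM, which is a limit of the assay and not a number. Compound 2 `O=C(CCCc1ccccc1)Nc1nc2ccccc2c(=O)s1` lacks that chloro. In this assay compound 2 gives > 1000 nM, again a limit of the assay. The step that the two limits leave unreadable from compound 1 to compound 2 is therefore unreadable, both ends resting at the limit of > 1000 nM in this assay, at which 3 of the 3 values shown sit. The change made is hydrogen in place of chloro on an aromatic carbon.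

Compound 3 `O=C(C/C=C/c1cccc(Cl)c1)Nc1nc2ccccc2c(=O)s1` carries an unsaturated chain ending in 3-chlorophenyl; the difference between the cores of compound 1 and compound 3 is not broken down here. In this assay compound 3 gives > 1000 nM, a limit of the assay. Compound 4 `O=C(C/C=C/c1ccccc1)Nc1nc2ccccc2c(=O)s1` is not yet measured and differs from compound 3 by hydrogen in place of chloro on an aromatic carbon. This is the same kind of change as from compound 1 to compound 2, not the same: in compound 1 the chloro sits on a ring that is part of a fused or bridged system of two rings, meta to a fused ring and para to a fused ring, whereas in compound 3 it sits on a six-membered aromatic ring of carbon only, meta to a large group. The earlier step gave no readable size because all three values sit at the limit of > 1000 nM in this assay, at which 3 of the 3 values shown sit.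

For compound 4 the step that the limit leaves unreadable from compound 3 to compound 4 is expected to be small. Compound 4 is expected to give 3000 nM, within a range from 800 nM to 20000 nM, most likely reported again only as a limit.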

Compound 4, inhibition constant: 158 nM
For compound 4 the middle estimate is 19-fold (1.28 log units) above the measured one, and the stated range ends above it.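

In this assay, hydrogen in place of chloro on the six-membered aromatic ring of carbon only gives an at least 6.3-fold lower number from compound 3 to compound 4 (0.80 log units; beyond the scatter); this size is only a floor, as one end of the step is a limit of the assay and not a number. The same kind of change in the core of compound 1, at a different place, cannot be read, as both of its ends are limits of the assay and not numbers: the limit of > 1000 nM in this assay, at which 3 of the 4 values shown sit. The series therefore holds one readable case, on one chain and at one place, and it shows neither that the change carries from one core to another nor that it fails to carry, as any shift from compound 1 to compound 2 would stay hidden behind the limits.

Still open, on these data alone, is whether a chloro placed on the core of compound 4 would keep a number below the limit, which would test the fused part of the core directly against the phenyl end. Also open, as far as these compounds go, is whether fluoro, methoxy or an amine in place of the chloro of compound 3 would read as hydrogen does, and whether a longer chain would hold the value of compound 4 at 158 nM.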